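The source may report more compounds than this note shows. Statements on the series, on what has been measured and on what is new or still open speak of the compounds shown alone.

Compound 1 `O=C(Nc1ccc2[nH]c(=O)[nH]c2c1)[C@H]1CCCN1C(=O)C1(c2cccc(Cl)c2)CCCC1` is the most polar of the three measured compounds in a physicochemical assay for lipophilicity, at pH 7.4 (a higher number here means a more lipophilic compound, a lower number a more polar compound), giving 4.4; compound 3 `O=C(Nc1ccc2[nH]ncc2c1)[C@H]1CCCN1C(=O)C1(c2cccc(Cl)c2)CCCC1` gives 5.4 and compound 2 `CNC(=O)c1cccc(NC(=O)[C@H]2CCCN2C(=O)C2(c3cccc(Cl)c3)CCCC2)c1` gives 5.5, so compound 1 sits below both. Compound 4 `O=C(Nc1ccc2[nH]ccc2n1)[C@H]1CCCN1C(=O)C1(c2cccc(Cl)c2)CCCC1` differs from compound 1 by a group of 9 heavy atoms (7 carbon, 2 nitrogen; one five-membered aromatic ring with 1 hetero atom, one six-membered aromatic ring with 1 hetero atom) in place of a group of 10 heavy atoms (7 carbon, 2 nitrogen, 1 oxygen; one five-membered aromatic ring with 2 hetero atoms, one six-membered aromatic ring of carbon only), on an amide-type nitrogen. The closest measured precedent is the step of a number 1.00 log units higher from compound 1 to compound 3 (beyond the scatter), which also swapped in a nine-atom bicyclic group lacking the oxygen; the step of a number 1.10 log units higher from compound 1 to compound 2 (beyond the scatter) was of similar size. A comparable rise in this assay is therefore expected for compound 4, estimated as a number 0.80 log units higher from compound 1 to compound 4 (beyond the scatter). Compound 4 is expected to give about 5.2, within a range of 4.7 to 5.7.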

Compound 4, distribution coefficient: 5.9
Compound 4: the middle estimate sits 0.70 log units below what was measured; the measured number lies above the stated range.
By their numbers in this assay, from the lowest: compound 1; then compounds 3 and 2 (each within the scatter of the next); then compound 4.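

Within the data shown here, at this place on the amide-type nitrogen, this assay reaches further than the earlier compounds showed, with a number 1.50 log units higher from compound 1 to compound 4 (beyond the scatter) and a number 0.40 log units higher from compound 2 to compound 4 (beyond the scatter). The groups of compound 3 and compound 4 have the same counts of heavy atoms, carbon and nitrogen, yet the record shows a number 0.50 log units higher from compound 3 to compound 4 (beyond the scatter), so removing the oxygen does not set the number alone; the change in the rings also goes with a shift.

Nothing available explains these steps. From the compounds shown here alone, how an amine or a carboxylic acid on the group of compound 4 would read in this assay remains open.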